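This account rests on a few compounds, and the source may have more. Where it says the series, first, only, none or still open, it means among the compounds named here.

Compound 2 `COc1cc2c(cc1OC)CN(CCCCNC(=O)c1ccc(-c3cn(CCOCCF)nn3)cc1)CC2` and compound 1 `COc1cc2c(cc1OC)CN(CCNC(=O)c1cn(-c3ccccc3OC)nn1)CC2` are both weak binders in an assay on membranes from brain for displacement of a labelled ligand from Sigma non-opioid intracellular receptor 1 (Cavia porcellus), read by scintillation counting, with a stated time of 90 min; on this read-out lower numbers stand for stronger inhibition and higher numbers for weaker inhibition: compound 2 gives 14700 nM, and compound 1 gives 15500 nM, the two numbers lying within the scatter of each other. Compound 3 `COc1ccc(Cn2cc(-c3ccc(C(=O)NCCCCN4CCc5cc(OC)c(OC)cc5C4)cc3)nn2)cc1` differs from compound 2 by 4-methoxyphenyl in place of (2-fluoroethoxy)methyl on a saturated chain carbon bound to an aromatic nitrogen. Among the compounds with values here, no measured pair shows this change, so its effect is unknown. Since compound 2 gives 14700 nM, compound 3 is expected to bind somewhat more strongly, by about a 1.8-fold lower number from compound 2 to compound 3 (0.26 log units; within the scatter) in this assay. The estimate for compound 3 is 8000 nM, within a range of 2000 nM to 30000 nM.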

Compound 3, inhibition constant: 12600 nM
The estimate for compound 3 lay 1.6-fold (0.20 log units) below the measured number; the measured number falls inside the stated range.
By their numbers in this assay, from the lowest: compounds 3, 2 and 1 (each within the scatter of the next).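

In this assay the exchange of (2-fluoroethoxy)methyl for 4-methoxyphenyl, which brings in a six-membered aromatic ring of carbon only, gives a 1.2-fold lower number from compound 2 to compound 3 (0.07 log units; within the scatter) and leaves the two compounds impossible to tell apart. On this saturated chain carbon bound to an aromatic nitrogen, a ring-free chain and an aromatic ring therefore read alike, and both compounds remain weak binders. Nothing available accounts for this result. As far as these compounds go, whether an amine or a carboxylic acid at this position would give a number clearly apart from these remains open.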